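This account rests on a few compounds, and the source may have more. Where it says the series, first, only, none or still open, it means among the compounds named here.

Measured so far in a functional assay on PC-3 cells (Homo sapiens) for antiproliferative activity, read by MTT assay, with a stated time of 48 h; on this read-out lower numbers stand for stronger inhibition and higher numbers for weaker inhibition: compound 1 `COc1cc(O)ccc1N1CCN(CC(O)COc2cccc3ccccc23)CC1` gives 24400 nM; compound 2 `Oc1ccccc1N1CCN(CC(O)COc2ccc(O)c3ccccc23)CC1` gives 26100 nM.

Compound 2 and compound 1 lie within the scatter of each other, so neither stands apart on the numbers shown. Compound 3 `Oc1ccccc1N1CCN(CC(O)COc2cccc3ccccc23)CC1` differs from compound 2 by hydrogen in place of hydroxy on an aromatic carbon. Among the compounds with values here, no measured pair shows this change by itself, and the two known values give no direction; a step in this assay no larger than the scatter is expected, if any. Compound 3 is therefore expected to give 24000 nM in this assay, with a range from 10000 nM to 60000 nM. The expected step is a 1.1-fold lower number from compound 2 to compound 3 (0.04 log units; within the scatter).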

Compound 3, half-maximal inhibitory concentration: 21700 nM
Compound 3: middle estimate off by 1.1-fold (0.04 log units), on the high side, and the stated range covers the measured number.
By their numbers in this assay, from the lowest: compounds 3, 1 and 2 (each within the scatter of the next).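

Hydrogen in place of hydroxy on this aromatic carbon, para to a large group, gives a 1.2-fold lower number from compound 2 to compound 3 (0.08 log units; within the scatter) in this assay, so this hydroxy does not set compound 2 apart on these numbers. Likewise, 2-hydroxyphenyl in place of 4-hydroxy-2-methoxyphenyl on the ring amine nitrogen gives a 1.1-fold lower number from compound 1 to compound 3 (0.05 log units; within the scatter) and does not separate the two compounds. No evidence bearing on these results is available. Going by these compounds, it remains open whether an amine or a carboxylic acid on this aromatic carbon would give a step beyond the scatter.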